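Amide partner swap on a shared core

The source may report more compounds than this note shows. Statements on the series, on what has been measured and on what is new or still open speak of the compounds shown alone.

Compound 1 `Cn1cc(CNS(=O)(=O)c2ccccc2Nc2cc(-c3ccc4ccn(C)c4c3)c3nccnc3c2)cn1` gives 38 nM in an assay for inhibition of 6-phosphofructo-2-kinase/fructose-2,6-bisphosphatase 3 (Homo sapiens), read by ADP-Glo, with a stated time of 2 h; on this read-out lower numbers stand for stronger inhibition and higher numbers for weaker inhibition.
Compound 2 `Cn1ccc2ccc(-c3cc(Nc4ccccc4S(=O)(=O)NCC4CCOCC4)cc4nccnc34)cc21` gives 26 nM in this assay.
Compound 3 `Cn1cc(NC(=O)c2ccncc2Nc2cc(-c3ccc4ccn(C)c4c3)c3nccnc3c2)cn1` gives 33 nM in this assay.

The three measured compounds sit close together: compound 3 is within the scatter of both compound 1 and compound 2, so none of them can be called stronger or weaker than another. Compound 4 `CN1CCC(N(C)C(=O)c2ccncc2Nc2cc(-c3ccc4ccn(C)c4c3)c3nccnc3c2)C1` is not yet measured. It differs from compound 3 in one place: methyl(1-methylpyrrolidin-3-yl)amino in place of (1-methyl-1H-pyrazol-4-yl)amino on a carbonyl carbon. Among the compounds with values here, the only measured step that resembles this change is a 1.5-fold lower number from compound 1 to compound 2 (0.16 log units; within the scatter), where an aromatic five-membered ring on a side chain also gave way to a saturated ring without any shift beyond the scatter. Within the data shown here, that step, however, sits on a sulfonamide nitrogen rather than on a carbonyl carbon, and no measured pair shows the loss of the amide hydrogen-bond donor that occurs here. The expectation is therefore a small step, a 1.4-fold higher number from compound 3 to compound 4 (0.13 log units; within the scatter), in no clear direction. Compound 4 is estimated at 45 nM, with a likely range from 15 nM to 150 nM.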

Compound 4, half-maximal inhibitory concentration: 176 nM
For compound 4 the middle estimate is 3.9-fold (0.59 log units) below the measured one; measured number above the stated range.
By their numbers in this assay, from the lowest: compounds 2, 3 and 1 (each within the scatter of the next); then compound 4.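

On the carbonyl carbon, this swap gives the first step among the compounds shown that lies beyond the scatter in this assay, with a 5.3-fold higher number from compound 3 to compound 4 (0.73 log units; beyond the scatter) as the result. The position is therefore not indifferent to what is attached, and a 1.5-fold lower number from compound 1 to compound 2 (0.16 log units; within the scatter) on the sulfonamide side chain does not carry over to this place. The swap alters several things together, since the five-membered aromatic ring with 1 hydrogen-bond donor gives way to a five-membered non-aromatic ring with 0 donors, and nothing here shows which of these differences matters.

Still open, on these data alone, is how the ring change and the loss of the amide hydrogen each count on their own. A (1-methylpyrrolidin-3-yl)amino group, which keeps that hydrogen, or a methyl(1-methyl-1H-pyrazol-4-yl)amino group, which lacks it, would separate the two.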